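Fluorines in Place of Methoxy on the Carbonyl Carbon

The source may hold more compounds than are shown below. What is called first, only, known or untested is meant among the compounds shown, and "the series" means these compounds.

Three close relatives have been measured in a functional assay on 786-0 cells (Homo sapiens) for cytotoxicity, read by sulforhodamine B assay, with a stated time of 48 h, tested at 0.01 uM; on this read-out lower numbers stand for a stronger effect and higher numbers for a weaker effect at the one concentration tested. Compound 1 `COc1cc(-c2cc(/C=C/C(=O)c3ccc(N)cc3)[nH]n2)cc(OC)c1OC` gives 92%, compound 2 `COc1ccc(C(=O)/C=C/c2cc(-c3cc(OC)c(OC)c(OC)c3)n[nH]2)cc1OC` gives 96%, and compound 3 `COc1ccc(C(=O)/C=C/c2cc(-c3cc(OC)c(OC)c(OC)c3)n[nH]2)cc1` gives 98%. All three numbers lie close together: the step of a number 4 percentage points higher from compound 1 to compound 2 (within the scatter) exchanges the whole ring on the carbonyl carbon, the step of a number 6 percentage points higher from compound 1 to compound 3 (within the scatter) exchanges one group on that ring, and the step of a number 2 percentage points higher from compound 2 to compound 3 (within the scatter) removes one group from it. Compound 3 sits inside this narrow band, with compound 2 as its nearest neighbour and compound 1 as its furthest.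

Compound 4 `COc1cc(-c2cc(/C=C/C(=O)c3ccc(F)c(F)c3)[nH]n2)cc(OC)c1OC` is the next member. Its change from compound 3 is 3,4-difluorophenyl in place of 4-methoxyphenyl on a carbonyl carbon. For the measured compounds named here, the closest precedent is a number 4 percentage points higher from compound 1 to compound 2 (within the scatter), where the whole ring on the carbonyl carbon was likewise swapped; the smaller edits a number 6 percentage points higher from compound 1 to compound 3 (within the scatter) and a number 2 percentage points higher from compound 2 to compound 3 (within the scatter) also stayed inside the scatter. Going by the values given here, no measured compound carries fluorine, so nothing directly tests this group, but every change made so far at this end of the molecule left the read-out unmoved within the scatter. Compound 4 is therefore expected to give 96%, with a range from 86% to 104%. The expected step of a number 2 percentage points lower from compound 3 to compound 4 (within the scatter) is thus one that stays within the scatter.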

Compound 4, a percentage reported as activity, at one concentration (the size of the read-out at that concentration, not a potency): 95%
Compound 4: the middle estimate sits 1 percentage points above what was measured, within the range that was stated.
By their numbers in this assay, from the lowest: compounds 1, 4, 2 and 3 (each within the scatter of the next).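

Fluorine now appears on the ring at the carbonyl carbon, and in this assay this ring cannot be told apart from the three before it: replacing 4-methoxyphenyl gives one small step (a number 3 percentage points lower from compound 3 to compound 4 (within the scatter)), replacing 3,4-dimethoxyphenyl gives another (a number 1 percentage points lower from compound 2 to compound 4 (within the scatter)), and replacing 4-aminophenyl gives a third (a number 3 percentage points higher from compound 1 to compound 4 (within the scatter)). For the compounds shown here, the position therefore tolerates a wider range of rings than the earlier compounds could show, since it now holds rings bearing amino, methoxy and fluorine, and the swap from 4-methoxyphenyl to 3,4-difluorophenyl takes the count of hydrogen-bond acceptors on the ring from 1 to 0 with no change beyond the scatter. Nothing available explains why the read-out stays so level across these four compounds.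

Going by these compounds, whether any group at this position can move the read-out remains open, for instance a ring carrying a carboxylic acid or a trifluoromethyl group, or a plain alkyl chain in place of the ring. A single low concentration also leaves open whether these four compounds would still look alike at higher concentrations, where a real difference between them might appear.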